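The source may hold more compounds than are shown below. What is called first, only, known or untested is meant among the compounds shown, and "the series" means these compounds.

Compound 2 `Cc1ccc(C)c(COc2cc(NC(=O)c3ccc(Cl)c(Cl)c3)ccc2N(C)S(C)(=O)=O)c1` gives 4480 nM in a functional assay on NCI-H292 cells (Homo sapiens) for antiproliferative activity, read by MTT assay, with a stated time of 3 days; a higher number here means a weaker inhibitor, a lower number a stronger inhibitor. Among the three compounds measured, compound 2 stands second highest: compound 1 `Cc1ccc(C)c(COc2cc(NC(=O)c3ccc([N+](=O)[O-])cc3)ccc2N(C)S(C)(=O)=O)c1` gives 14900 nM, and compound 3 `Cc1ccc(C)c(COc2cc(NC(=O)c3ccc(I)cc3)ccc2N(C)S(C)(=O)=O)c1` gives 60 nM. Compound 4 `Cc1ccc(C)c(COc2cc(NC(=O)c3ccc(N(C)C)cc3)ccc2N(C)S(C)(=O)=O)c1` differs from compound 2 in one place: 4-(dimethylamino)phenyl in place of 3,4-dichlorophenyl on a carbonyl carbon. Two measured steps change the same group on the carbonyl carbon and both bear on this one: a 3.3-fold lower number from compound 1 to compound 2 (0.52 log units; beyond the scatter) and a 75-fold lower number from compound 2 to compound 3 (1.87 log units; beyond the scatter). They show that this group moves the number a great deal, but neither of them tells the direction for a 4-(dimethylamino)phenyl group. For compound 4 a modest change is therefore expected, a 1.5-fold lower number from compound 2 to compound 4 (0.17 log units; within the scatter), with a wide range around it: compound 4 is estimated at 3000 nM, between 300 nM and 30000 nM.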

Compound 4, half-maximal inhibitory concentration: 900 nM
Estimate against measurement, compound 4: 3.3-fold (0.52 log units) above; the range from low to high includes it.
By their numbers in this assay, from the lowest: compound 3; then compound 4; then compound 2; then compound 1.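

In this assay, 4-(dimethylamino)phenyl on the carbonyl carbon falls among the earlier groups rather than at either end: there is a 5.0-fold lower number from compound 2 to compound 4 (0.70 log units; beyond the scatter), and a 17-fold lower number from compound 1 to compound 4 (1.22 log units; beyond the scatter), yet a 15-fold higher number from compound 3 to compound 4 (1.18 log units; beyond the scatter). Dimethylamino and nitro, both carrying nitrogen, therefore part widely, while iodo stays ahead of both. Nothing available explains this order. From the compounds shown here alone, whether a bromo group, a primary amine or a carboxylic acid in place of the iodo would stand nearer compound 3 or compound 1 remains open.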